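The compounds below may be only part of what the source reports. "The series", "measured", "known", "first", "only" and "open" are said of these compounds alone.

Working notes on the series. All numbers come from a functional assay on KB cells (Homo sapiens) for antiproliferative activity, read by sulforhodamine B assay, with a stated time of 3 days; a higher number here means that more compound is needed for the effect, a lower number that less compound is needed. Compound 1 `CCC1=C(O)c2c(oc(-c3ccc(O)cc3)cc2=O)C(CC)(CC)C1=O` gives 20.6 uM in this assay. For the measured compounds named here, compound 2 `CCC1=C(O)c2c(oc(-c3ccc(C)cc3C)cc2=O)C(CC)(CC)C1=O` gives 41.2 uM in this assay, the higher of the two numbers measured so far; its nearest neighbour is compound 1, and the step of a 2.0-fold higher number from compound 1 to compound 2 (0.30 log units; within the scatter) lies within the scatter, so no order between the two can be claimed. The next compound is compound 3 `CCC1=C(O)c2c(oc(-c3ccc(O)c(C)c3C)cc2=O)C(CC)(CC)C1=O`, not yet measured in this assay. The change from compound 2 to compound 3 is 4-hydroxy-2,3-dimethylphenyl in place of 2,4-dimethylphenyl on an aromatic carbon. Going by the values given here, the only measured step that bears on it is a 2.0-fold higher number from compound 1 to compound 2 (0.30 log units; within the scatter), in which 2,4-dimethylphenyl replaced 4-hydroxyphenyl and the number stayed within the scatter. Compound 3 brings the hydroxy seen in compound 1 back while keeping the methyl groups of compound 2, so on these numbers no step beyond the scatter is expected, with the number for compound 3 expected near that of compound 2 or somewhat lower. The estimate for compound 3 in this assay is 25 uM, with a range of 10 uM to 60 uM. The step expected is a 1.6-fold lower number from compound 2 to compound 3 (0.22 log units; within the scatter).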

Compound 3, concentration for half-maximal effect: 6.5 uM
Beside the measured number, compound 3's estimate is 3.8-fold (0.59 log units) above it; measured number below the stated range.
By their numbers in this assay, from the lowest: compound 3; then compounds 1 and 2 (each within the scatter of the next).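

This position, an aromatic carbon next to the ring oxygen, now gives a step beyond the scatter in this assay, which the earlier pair did not show. Placing 4-hydroxy-2,3-dimethylphenyl there instead of 2,4-dimethylphenyl gives a 6.3-fold lower number from compound 2 to compound 3 (0.80 log units; beyond the scatter), and placing it there instead of 4-hydroxyphenyl gives a 3.2-fold lower number from compound 1 to compound 3 (0.50 log units; beyond the scatter), so the group that carries the hydroxy together with the 2,3-dimethyl arrangement stands apart from both earlier groups, whereas those two groups could not be ordered against each other. Nothing at hand accounts for this difference.

The compounds shown do not separate the contributions of the two methyl groups in 4-hydroxy-2,3-dimethylphenyl, as neither 4-hydroxy-2-methylphenyl nor 4-hydroxy-3-methylphenyl is among them, and a single-methyl group would be needed to tell whether one methyl suffices. Also open, as far as these compounds go, is whether the hydroxy itself is needed alongside the two methyl groups, a question that a methoxy, an amine or a carboxylic acid in its place would address, and whether the step holds when the ethyl groups on the shared core are exchanged for a longer chain.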